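The source may hold more compounds than are shown below. What is called first, only, known or untested is meant among the compounds shown, and "the series" means these compounds.

Measured compounds:
Compound 1 `CCc1cccc(C)c1-n1nncc1CN1C(=O)C2(C(C#N)=C(N)Oc3c(N)cc4nc5ccccc5nc4c32)c2ccccc21`. In an ADME assay on L02 cells (Homo sapiens) for antiproliferative activity, read by MTT assay, with a stated time of 48 h (on this read-out lower numbers stand for stronger inhibition and higher numbers for weaker inhibition), compound 1 gives > 50000 nM, a limit of the assay and not a number.
Compound 2 `Cc1ccc(C)c(-n2nncc2CN2C(=O)C3(C(C#N)=C(N)Oc4c(N)cc5nc6ccccc6nc5c43)c3ccccc32)c1`. In this assay compound 2 gives > 50000 nM, likewise a limit.

Among the measured compounds shown here, compound 2 thus stands only at the limit of this assay, and the one other value shown sits at the same limit (the limit of > 50000 nM in this assay, at which 2 of the 2 values shown sit). For the measured compounds named here, the single measured step, a step that the two limits leave unreadable from compound 1 to compound 2, lies between two limits and gives no readable size. Compound 3 `N#CC1=C(N)Oc2c(N)cc3nc4ccccc4nc3c2C12C(=O)N(Cc1cnnn1-c1ccc(F)c(Cl)c1)c1ccccc12` carries the change (3-chloro-4-fluorophenyl in place of 2,5-dimethylphenyl on an aromatic nitrogen). No measured step bears on this change, and the one step shown cannot be read, so nothing here points in either direction beyond the scatter. For compound 3 the step that the limit leaves unreadable from compound 2 to compound 3 is expected to be none beyond the scatter, with the value most likely reported again only as a limit. Compound 3 is estimated at 60000 nM, in the range 15000 nM to 250000 nM.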

Compound 3, half-maximal inhibitory concentration: > 50000 nM
Compound 3: only a limit was reported; the forecaster's own chance of this, stated with the estimate: 80%; the middle value lies beyond the limit too.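

No new step can be read between compound 1, compound 2 and compound 3, since all three sit at a limit of the assay and not at a number: the limit of > 50000 nM in this assay, at which 3 of the 3 values shown sit.

The compounds shown leave open whether the 2-ethyl-6-methylphenyl, 2,5-dimethylphenyl and 3-chloro-4-fluorophenyl groups on the aromatic nitrogen differ at all on this read-out.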